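Methyl on the anilino ring of a lactone lignan

The source may report more compounds than this note shows. Statements on the series, on what has been measured and on what is new or still open speak of the compounds shown alone.

Measured so far, in an ADME assay on HeLa cells (Homo sapiens) for cytotoxicity, read by MTT assay; a higher number here means a weaker inhibitor, a lower number a stronger inhibitor:
Compound 1 `COc1ccc(C[C@H]2COC(=O)[C@@H]2Cc2ccc(OCC(=O)Nc3ccccc3)c(OC)c2)cc1OC` sits at the limit of the assay, >= 600000 nM.
Compound 2 `COc1ccc(C[C@H]2COC(=O)[C@@H]2Cc2ccc(OCC(=O)N3CCCCC3)c(OC)c2)cc1OC` gives 293000 nM.
Compound 3 `COC(=O)[C@@H](NC(=O)CCC(=O)Oc1ccc(C[C@H]2C(=O)OC[C@@H]2Cc2ccc(OC)c(OC)c2)cc1OC)c1c[nH]c2ccccc12` sits at the limit of the assay, >= 600000 nM.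

Compound 1 thus stands at the upper edge of what the assay reports: its value is a limit, not a number, and two of the three values shown sit there (the limit of >= 600000 nM in this assay, at which 2 of the 3 values shown sit). For the measured compounds named here, the only step measured between single-point neighbours is an at least 2.0-fold lower number from compound 1 to compound 2 (0.31 log units; beyond the scatter), which moved the value down from the limit into the measured range.

Compound 4 `COc1ccc(C[C@H]2COC(=O)[C@@H]2Cc2ccc(OCC(=O)Nc3ccc(C)cc3)c(OC)c2)cc1OC` differs from compound 1 by methyl in place of hydrogen on an aromatic carbon. Going by the values given here, no measured step touches this change; the one step known alters the amide nitrogen substituent altogether, not a ring carbon on the anilino group. The change is small, and so in this assay compound 4 is expected to show a number no higher from compound 1 to compound 4 (the limit leaves the size open), most likely remaining at the limit. The estimate for compound 4 is 600000 nM, between 250000 nM and 1200000 nM.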

Compound 4, half-maximal inhibitory concentration: 228000 nM
Estimate against measurement, compound 4: 2.6-fold (0.42 log units) above; measured number below the stated range.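

In this assay, methyl in place of hydrogen on an aromatic carbon of the anilino ring gives an at least 2.6-fold lower number from compound 1 to compound 4 (0.42 log units; beyond the scatter), so this ring position responds to a single added carbon, which the earlier step, a change of the whole group on the carbonyl carbon, could not show. Putting (4-methylphenyl)amino in place of piperidin-1-yl gives a 1.3-fold lower number from compound 2 to compound 4 (0.11 log units; within the scatter), so these two quite different groups cannot be told apart here. The value of compound 1 is a limit and not a number, so the true size of the methyl step stays unknown because of where that value sits: the limit of >= 600000 nM in this assay, at which 2 of the 4 values shown sit.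

On these data alone, whether an ethyl group, a chlorine or a hydroxyl group on the same ring carbon would act as methyl does remains open. So does the effect of a methyl group on another carbon of that ring.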